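A few compounds are considered here, and "the series" means these few. Any claim that something is new, unique, unknown or untested is made for them only; others in the source may bear on it.

The account concerns three measured compounds and a fourth awaiting measurement in a functional assay on the whole organism (uterus) with Rattus norvegicus as the target, tested at 50 uM; on this read-out higher numbers stand for a weaker effect at the one concentration tested and lower numbers for a stronger effect. Compound 1 `CC(C)Nc1nc(O)c2cc(Cl)ccc2n1` gives 61% in this assay. Compound 3 `CC(C)Nc1nc(O)c2cc(I)ccc2n1` keeps the core of compound 1 and differs from it only by iodo in place of chloro on an aromatic carbon; in this assay compound 3 gives 41%. That change produced a step of a number 20 percentage points lower from compound 1 to compound 3 (beyond the scatter). Compound 2 `Oc1nc(NCC2CCCCC2)nc2ccc(Cl)cc12` gives the highest number of the three in this assay, 80.3%; the difference between the cores of compound 2 and compound 1 is not broken down here. Compound 4 `Oc1nc(NCC2CCCCC2)nc2ccc(I)cc12` is obtained from compound 2 by iodo in place of chloro on an aromatic carbon, the same change as that from compound 1 to compound 3, at a place described in the same words. The change has been observed only once among the measured compounds, so any expectation rests on a single step. From compound 2 to compound 4 a step of a number 20.3 percentage points lower from compound 2 to compound 4 (beyond the scatter) is expected, because a number 20 percentage points lower from compound 1 to compound 3 (beyond the scatter) was the outcome of the same change on the core of compound 1. Compound 4 is therefore estimated to give 60% in this assay, with a range from 45% to 75%.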

Compound 4, a percentage reported as activity, at one concentration (the size of the read-out at that concentration, not a potency): 97.9%
Compound 4: the middle estimate sits 37.9 percentage points below what was measured, outside the stated range (above it).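

In this assay, iodo in place of chloro on an aromatic carbon gave a number that moved the opposite way on the second core, so the step seen on the core of compound 1 did not carry over to the core of compound 2: the same change on two cores in this assay, a number 20 percentage points lower (beyond the scatter) from compound 1 to compound 3 and a number 17.6 percentage points higher (beyond the scatter) from compound 2 to compound 4, 37.6 percentage points apart, beyond the scatter of two such steps The new step reads a number 17.6 percentage points higher from compound 2 to compound 4 (beyond the scatter), which shows that in this series the direction of this change cannot be taken from one core and applied to another. It does not show which difference between the two cores goes with the reversal, nor why the sign changes, and two pairs give no rule for any third core.

The compounds shown leave open how fluoro or bromo on the same aromatic carbon would behave on either core, and whether such values would fall in order with those of chloro and iodo. They also leave open what the same change does on a core that carries a longer chain or a simple benzyl group on the amine nitrogen.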